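Working notes on compound 3 and compound 4

The compounds below may be only part of what the source reports. "The series", "measured", "known", "first", "only" and "open" are said of these compounds alone.

- Compound 1 `O=S(=O)(NCCNC(=S)Nc1cc(C(F)(F)F)cc(C(F)(F)F)c1)c1ccc(-c2ccccc2O[C@H]2CC[C@@H](O)CC2)s1` in a functional assay on HL-60 cells (Homo sapiens) for inhibition, read by CCK-8 assay, with a stated time of 48 h (on this read-out lower numbers stand for stronger inhibition and higher numbers for weaker inhibition), gives 2600 nM as a number
- Compound 2 `COc1ccc(Oc2ccccc2-c2ccsc2S(=O)(=O)NCCNC(=S)Nc2cc(C(F)(F)F)cc(C(F)(F)F)c2)cc1OC` in this assay gives 2800 nM as a number
- Compound 3 `COc1ccc(Oc2ccccc2-c2ccsc2S(=O)(=O)N2CCN(C(=O)Nc3cccc([N+](=O)[O-])c3)CC2)cc1OC` in this assay gives > 50000 nM as a limit, not a number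

Compound 1 and compound 2 lie within the scatter of each other. Compound 3 stands at the limit of > 50000 nM in this assay, at which 1 of the 3 values shown sits, and so carries a limit only.

Compound 4 `COc1ccc(Oc2ccccc2-c2ccsc2S(=O)(=O)N2CCN(C(=O)Nc3ccc(F)cc3)CC2)cc1OC` keeps the rest of compound 3 and carries 4-fluorophenyl in place of 3-nitrophenyl on an amide-type nitrogen, counted as 4-fluorophenyl in place of 3-nitrophenyl on an amide-type nitrogen in this change.

Among the compounds with values here, no measured pair in this assay isolates this change, so the expectation rests on one compound alone. Compound 4 is expected to stay close to compound 3, whose value of > 50000 nM is a limit of the assay. The expected step is an at least 1.5-fold lower number from compound 3 to compound 4 (0.19 log units; that floor lies within the scatter) and would be small, toward stronger inhibition if it shows at all. The estimate for compound 4 is 32000 nM with an expected range from 10000 nM to 50000 nM in this assay and a good chance of a limit only.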

Compound 4, half-maximal inhibitory concentration: > 20000 nM
Compound 4: only a limit was reported (the forecaster's own chance of this, stated with the estimate: 60%); the middle value does not contradict the limit.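

Compound 3 stands at > 50000 nM in this assay as a limit, not a number. Compound 4 stands at > 20000 nM as a limit as well. With only these two limits, no step can be read between compound 3 and compound 4. The compounds shown leave open whether 4-fluorophenyl in place of 3-nitrophenyl on an amide-type nitrogen changes inhibition at all.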